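This account rests on a few compounds, and the source may have more. Where it says the series, first, only, none or still open, it means among the compounds named here.

Measured compounds and their values:

In an ADME assay on Vero cells (Chlorocebus sabaeus) for cytotoxicity, read by MTT assay, with a stated time of 72 h (on this read-out lower numbers stand for higher toxicity in this test and higher numbers for lower toxicity in this test), compound 1 `O=C(C1CC1)N1CCN(c2nc(=O)c3cc(C(F)(F)F)cc([N+](=O)[O-])c3s2)CC1` gives > 125000 nM, a limit of the assay rather than a number.
Compound 2 `O=C(c1ccc(F)cc1)N1CCN(c2nc(=O)c3cc(C(F)(F)F)cc([N+](=O)[O-])c3s2)CC1` gives > 125000 nM, likewise a limit.
Compound 3 `CCC(C)C(=O)N1CCN(c2nc(=O)c3cc(C(F)(F)F)cc([N+](=O)[O-])c3s2)CC1` gives > 125000 nM, again a limit.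

Compound 2 stands at the limit of > 125000 nM in this assay, at which 3 of the 3 values shown sit. The change from compound 2 to compound 4 `CC(C)(C)C(=O)N1CCN(c2nc(=O)c3cc(C(F)(F)F)cc([N+](=O)[O-])c3s2)CC1` is tert-butyl in place of 4-fluorophenyl on a carbonyl carbon. The measured steps that touch the same carbonyl carbon bear on it: a step that the two limits leave unreadable from compound 1 to compound 2, a step that the two limits leave unreadable from compound 1 to compound 3 and a step that the two limits leave unreadable from compound 2 to compound 3. None of them can be read: both ends of each sit at the limit. They show only that cyclopropyl, 4-fluorophenyl and sec-butyl on this carbonyl carbon all give a limit and nothing more in this assay. With tert-butyl entering on the same carbon, no step beyond the scatter is expected in this assay, and the most likely outcome is a fourth limit. The estimate for compound 4 is 200000 nM, with a range from 100000 nM to 400000 nM. That estimate means an expected step that the limit leaves unreadable from compound 2 to compound 4.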

Compound 4, half-maximal cytotoxic concentration: > 125000 nM
Compound 4 was reported as a limit; the forecaster's own chance of this, stated with the estimate: 85%; the middle value lies beyond the limit too.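

In this assay compound 4 gives > 125000 nM, which is again a limit. No new step can be read from compound 1, compound 2 or compound 3 to compound 4: both ends of each sit at a limit. The compounds shown leave open whether any group on this carbonyl carbon would give a readable value.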